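Swapping trifluoromethyl for trifluoromethoxy on compound 1

The source may report more compounds than this note shows. Statements on the series, on what has been measured and on what is new or still open speak of the compounds shown alone.

Compound 1 `O=C(O)CCNC(=O)c1ccc(CN(c2ccc(Cl)cc2)c2nc(-c3ccc(C(F)(F)F)cc3)cs2)cc1` is one of three close relatives that share a core and differ only in the aromatic group attached to the nitrogen. In an in vitro assay on BHK cells for binding affinity to gastric inhibitory polypeptide receptor (Homo sapiens) (a lower number here means a stronger inhibitor, a higher number a weaker inhibitor), compound 1 gives 410 nM. Compound 2 `Cc1cc(N(Cc2ccc(C(=O)NCCC(=O)O)cc2)c2nc(-c3ccc(C(F)(F)F)cc3)cs2)ccc1C(C)C` gives 293 nM, and compound 3 `O=C(O)CCNC(=O)c1ccc(CN(c2ccc3c(c2)CCC3)c2nc(-c3ccc(C(F)(F)F)cc3)cs2)cc1` gives 510 nM. The three numbers sit together: a 1.4-fold lower number from compound 1 to compound 2 (0.15 log units; within the scatter), a 1.2-fold higher number from compound 1 to compound 3 (0.09 log units; within the scatter) and a 1.7-fold higher number from compound 2 to compound 3 (0.24 log units; within the scatter), so none of these changes at the nitrogen moves the result beyond the usual scatter, and compound 1 cannot be separated from the other two.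

Compound 4 `O=C(O)CCNC(=O)c1ccc(CN(c2ccc(Cl)cc2)c2nc(-c3ccc(OC(F)(F)F)cc3)cs2)cc1` is a new step from compound 1 in a different place: trifluoromethoxy in place of trifluoromethyl on an aromatic carbon. None of the three measured steps touches this part of the molecule; they all alter the group on the nitrogen and leave the trifluoromethylphenyl untouched. Among the measured compounds shown here, there is therefore no directly comparable step to lean on. What the three measured steps do show is that modest changes to the outer groups of this core have so far stayed within the scatter in this assay, and the exchange of trifluoromethyl for trifluoromethoxy is also a small change. The expectation for compound 4 is accordingly a result close to that of compound 1, with no step beyond the scatter, estimated as a 1.1-fold higher number from compound 1 to compound 4 (0.04 log units; within the scatter). Compound 4 is thus estimated at 450 nM, within a range of 150 nM to 1400 nM to reflect the absence of a guiding precedent.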

Compound 4, half-maximal inhibitory concentration: 460 nM
Compound 4: middle estimate off by 1.0-fold (0.01 log units), on the low side, within the range that was stated.
By their numbers in this assay, from the lowest: compounds 2, 1, 4 and 3 (each within the scatter of the next).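

Compound 4 is the first compound shown that alters the trifluoromethyl group rather than the aromatic group on the nitrogen, and in this assay this exchange gives a 1.1-fold higher number from compound 1 to compound 4 (0.05 log units; within the scatter). The earlier compounds shown here said nothing about this position, whereas this pair shows that, with the 4-chlorophenyl group kept on the nitrogen, trifluoromethoxy and trifluoromethyl cannot be told apart here, even though trifluoromethoxy brings in an oxygen and counts as a hydrogen-bond acceptor. No measurement on hand offers an explanation for this result.

With only these two groups shown at this position, the compounds leave open whether a very different group, such as an amine, a carboxylic acid or a longer alkyl chain, would give a step beyond the scatter. They also leave open whether trifluoromethoxy would give a similar result alongside the 4-isopropyl-3-methylphenyl group of compound 2 or the 2,3-dihydro-1H-inden-5-yl group of compound 3, since this exchange is shown only with the 4-chlorophenyl group on the nitrogen.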